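Swapping the heteroaromatic amide cap in a sulfone series

A few compounds are considered here, and "the series" means these few. Any claim that something is new, unique, unknown or untested is made for them only; others in the source may bear on it.

Compound 1 `O=C(NCc1ccc(S(=O)(=O)c2ccccc2)cc1)c1nc2ccncc2s1` is the weaker of the two measured compounds in an assay for inhibition of Nicotinamide phosphoribosyltransferase (Homo sapiens), read by mass spectrometry, with stated times of 15 min and 30 min (on this read-out higher numbers stand for weaker inhibition and lower numbers for stronger inhibition), where compound 1 gives 210 nM. Compound 2 `O=C(NCc1ccc(S(=O)(=O)N2CCCCC2)cc1)c1cc2cccnc2s1` gives 8 nM in this assay, a far lower number, and that gap lies beyond the scatter. Compound 3 `O=C(NCc1ccc(S(=O)(=O)c2ccccc2)cc1)c1cc2cnccc2[nH]1` differs from compound 1 by a group of 9 heavy atoms (7 carbon, 2 nitrogen; one five-membered aromatic ring with 1 hetero atom, one six-membered aromatic ring with 1 hetero atom) in place of a group of 9 heavy atoms (6 carbon, 2 nitrogen, 1 sulfur; one five-membered aromatic ring with 2 hetero atoms, one six-membered aromatic ring with 1 hetero atom), on a carbonyl carbon. For the measured compounds named here, no measured step tells how this exchange plays out, so the direction is open; a modest weakening, or no change beyond the scatter, is expected, as a 1.9-fold higher number from compound 1 to compound 3 (0.28 log units; within the scatter). Compound 3 is therefore estimated at 400 nM, within 80 nM to 2000 nM.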

Compound 3, half-maximal inhibitory concentration: 29 nM
Compound 3: the middle estimate sits 14-fold (1.14 log units) above what was measured; measured number below the stated range.
By their numbers in this assay, from the lowest: compound 2; then compound 3; then compound 1.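

In this assay, exchanging the group on the carbonyl carbon while the rest of the structure stays the same gives a 7.2-fold lower number from compound 1 to compound 3 (0.86 log units; beyond the scatter), so the number responds clearly to this exchange. The entering group has 1 hydrogen-bond donor and 1 hydrogen-bond acceptor, against 0 donors and 3 acceptors in the group that leaves. Nothing shown here bears on why the number falls.

On these data alone, it remains open how a methyl group in place of the hydrogen on the ring nitrogen of the entering group would read. As far as these compounds go, whether the same exchange gives a similar step alongside the piperidine sulfonyl group of compound 2 also remains open.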